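A few compounds are considered here, and "the series" means these few. Any claim that something is new, unique, unknown or untested is made for them only; others in the source may bear on it.

Compound 1 `CCCCc1ccc(CNC(=O)Nc2ccccc2)c(=O)n1Cc1ccc(-c2ccccc2-c2nn[nH]n2)cc1` gives 30 nM in a functional assay (aorta) for antagonist activity, with Oryctolagus cuniculus as the target; a higher number here means a weaker inhibitor, a lower number a stronger inhibitor.
Compound 2 `CCCCc1ccc(CNC(=O)NC2CCCCC2)c(=O)n1Cc1ccc(-c2ccccc2-c2nn[nH]n2)cc1` gives 90 nM in this assay.

Going by the values given here, compound 2 stands at the highest of the two numbers measured in this assay; the only other measured compound, compound 1, reached its lower number through the one step recorded, a 3.0-fold higher number from compound 1 to compound 2 (0.48 log units; beyond the scatter), where cyclohexyl replaced phenyl on an amide-type nitrogen.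

Compound 3 `CCCCNC(=O)NCc1ccc(CCCC)n(Cc2ccc(-c3ccccc3-c3nn[nH]n3)cc2)c1=O` differs from compound 2 by butyl in place of cyclohexyl on an amide-type nitrogen. Among the compounds with values here, the one measured step bears on it only loosely: it shows that exchanging phenyl for cyclohexyl at this nitrogen raised the number modestly, but no measured pair shows what happens when the ring at this position is opened to a chain. The expected step of a 1.7-fold higher number from compound 2 to compound 3 (0.22 log units; within the scatter) is therefore small, most likely none beyond the scatter or a slight move toward a higher number. Compound 3 is estimated at 150 nM, with a range from 50 nM to 500 nM.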

Compound 3, half-maximal inhibitory concentration: 10 nM
The estimate for compound 3 lay 15-fold (1.18 log units) above the measured number; the measured number lies below the stated range.
By their numbers in this assay, from the lowest: compound 3; then compound 1; then compound 2.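

The butyl chain gives the lowest number of the three groups placed on this amide-type nitrogen: the change from the saturated ring gives a 9.0-fold lower number from compound 2 to compound 3 (0.95 log units; beyond the scatter) and the change from the aromatic ring gives a 3.0-fold lower number from compound 1 to compound 3 (0.48 log units; beyond the scatter) in this assay. Among these compounds, then, a ring on this nitrogen is not needed for a low number, and the open chain beats both the cyclohexyl and the phenyl group. No measurement available here explains why the butyl chain gives the lowest number.

Three compounds cannot show whether a shorter chain such as ethyl, a longer chain such as hexyl, or a branched chain such as isobutyl would lower the number further. They also leave open what an amine or a carboxylic acid at the end of the butyl chain would do.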